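Nitro on the benzyl thioether of compound 2

A few compounds are considered here, and "the series" means these few. Any claim that something is new, unique, unknown or untested is made for them only; others in the source may bear on it.

In a functional assay on HepG2 cells (Homo sapiens) for antiproliferative activity, read by MTT assay, with a stated time of 24 h (a higher number here means a weaker inhibitor, a lower number a stronger inhibitor), compound 2 `c1ccc(CSc2nnc(-c3ccc4c(c3)OCCO4)n2-c2ccccc2)cc1` gives 5960 nM, the lower of the two numbers measured; compound 1 `Sc1nnc(-c2ccc3c(c2)OCCO3)n1-c1ccccc1` gives 60000 nM. Within the data shown here, the single measured step, a 10-fold lower number from compound 1 to compound 2 (1.00 log units; beyond the scatter), concerns benzyl in place of hydrogen on a sulfur. Compound 3 `O=[N+]([O-])c1ccccc1CSc1nnc(-c2ccc3c(c2)OCCO3)n1-c1ccccc1` keeps that benzyl thioether and differs from compound 2 only by nitro in place of hydrogen on an aromatic carbon. Among the measured compounds shown here, no measured step touches the benzyl ring itself, so nothing comparable is available for this change. For compound 3 the step is therefore expected to stay within the scatter, a 1.3-fold lower number from compound 2 to compound 3 (0.12 log units; within the scatter). Compound 3 is estimated at 4500 nM, between 1500 nM and 15000 nM.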

Compound 3, half-maximal inhibitory concentration: 12000 nM
The estimate for compound 3 lay 2.7-fold (0.43 log units) below the measured number; the range from low to high includes it.
By their numbers in this assay, from the lowest: compounds 2 and 3 (each within the scatter of the next); then compound 1.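

In this assay, nitro on the benzyl ring gives a 2.0-fold higher number from compound 2 to compound 3 (0.30 log units; within the scatter), so benzyl and 2-nitrobenzyl on the sulfur cannot be told apart here. The substituted ring still keeps a step beyond the scatter against the free sulfur, with a 5.0-fold lower number from compound 1 to compound 3 (0.70 log units; beyond the scatter). Among these compounds, no evidence on the compounds bears on this result.

Still open, on these data alone, is whether an amine or a carboxylic acid on the benzyl ring would read differently from nitro. Also open, as far as these compounds go, is how a longer chain between the sulfur and the ring would read.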